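Aminophenyl Replacing Methylpyrazolyl on a Thienopyridine Core

A few compounds are considered here, and "the series" means these few. Any claim that something is new, unique, unknown or untested is made for them only; others in the source may bear on it.

Compound 1 `COC(=O)c1sc2cc(-c3cccs3)cnc2c1N` in a functional assay on A-375 cells (Homo sapiens) for inhibition, read by sulforhodamine B assay, with a stated time of 48 h (on this read-out lower numbers stand for stronger inhibition of growth and higher numbers for weaker inhibition of growth), gives only a limit of the assay, > 150000 nM.
Compound 2 `COC(=O)c1sc2cc(-c3cnn(C)c3)cnc2c1N` in this assay likewise gives only a limit, > 150000 nM.

Among the measured compounds shown here, compound 2 therefore stands at the limit of > 150000 nM in this assay, at which 2 of the 2 values shown sit, and the one measured step, a step that the two limits leave unreadable from compound 1 to compound 2, cannot be read in size or direction. Compound 3 `COC(=O)c1sc2cc(-c3ccccc3N)cnc2c1N` differs from compound 2 by 2-aminophenyl in place of 1-methyl-1H-pyrazol-4-yl on an aromatic carbon. For the measured compounds named here, no measured step bears on this change beyond the two limits. The expected step is estimated as an at least 1.2-fold lower number from compound 2 to compound 3 (0.09 log units; that floor lies within the scatter), and this is merely the step that the estimate itself implies. Compound 3 is expected to give 120000 nM in this assay, within 20000 nM to 400000 nM, most likely again only a limit.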

Compound 3, concentration for 50% growth inhibition: 2500 nM
Estimate against measurement, compound 3: 48-fold (1.68 log units) above; the measured number lies below the stated range.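

In this assay, 2-aminophenyl in place of 1-methyl-1H-pyrazol-4-yl gives an at least 60-fold lower number from compound 2 to compound 3 (1.77 log units; beyond the scatter), and in place of thiophen-2-yl it gives an at least 60-fold lower number from compound 1 to compound 3 (1.77 log units; beyond the scatter). Compound 3 thus shows that a change at this aromatic carbon can bring a readable number, which neither earlier compound gave. Compound 2 remains at a limit of the assay: the limit of > 150000 nM in this assay, at which 2 of the 3 values shown sit.

The compounds shown leave open whether the gain rests with the amine or with the six-membered aromatic ring of carbon only. Plain phenyl, or a hydroxyl in place of the amine, would separate the two.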